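Fluoro to trifluoromethyl on the shared core

This account rests on a few compounds, and the source may have more. Where it says the series, first, only, none or still open, it means among the compounds named here.

Compound 1 `Oc1ccc(-c2cc(-c3cccc(F)c3)cc(-c3ccccc3O)n2)cc1`: > 50000 nM
Compound 2 `Oc1ccc(-c2cc(-c3cccc(F)c3)cc(-c3ccc(O)cc3)n2)cc1`: 9290 nM

Of the compounds shown here, two have been measured in a functional assay on DU-145 cells (Homo sapiens) for inhibition; a lower number here means a stronger inhibitor, a higher number a weaker inhibitor. Compound 1 `Oc1ccc(-c2cc(-c3cccc(F)c3)cc(-c3ccccc3O)n2)cc1` reaches only the limit of the assay, > 50000 nM, and no number is known for it (the limit of > 50000 nM in this assay, at which 1 of the 2 values shown sits). Compound 2 `Oc1ccc(-c2cc(-c3cccc(F)c3)cc(-c3ccc(O)cc3)n2)cc1` gives 9290 nM, which is the only number shown, so compound 2 stands alone as a measured value. Among the compounds with values here, the single measured step, an at least 5.3-fold lower number from compound 1 to compound 2 (0.73 log units; beyond the scatter), concerns 4-hydroxyphenyl in place of 2-hydroxyphenyl on an aromatic carbon.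

Compound 3 `Oc1ccc(-c2cc(-c3cccc(C(F)(F)F)c3)cc(-c3ccc(O)cc3)n2)cc1` is not yet measured. It differs from compound 2 by trifluoromethyl in place of fluoro on an aromatic carbon. Within the data shown here, no measured step touches this change: the one known step alters a different ring, so nothing in the data sets the direction or size of what the trifluoromethyl group will do. Compound 3 is therefore expected to sit close to compound 2, with a step of a 1.2-fold lower number from compound 2 to compound 3 (0.09 log units; within the scatter) that is estimated to stay within the usual scatter. The estimate for compound 3 in this assay is 7500 nM, within a range of 2500 nM to 25000 nM.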

Compound 3, half-maximal inhibitory concentration: > 50000 nM
Compound 3: no number, only a limit; the forecaster's own chance of this, stated with the estimate: 10%; middle value at least 6.6-fold (0.82 log units) from the limit.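

In this assay, within the data shown here, the change from 3-fluorophenyl to 3-(trifluoromethyl)phenyl gives an at least 5.3-fold higher number from compound 2 to compound 3 (0.73 log units; beyond the scatter), so the ring that no earlier step touched is not indifferent to the group it carries. Compound 3 gives > 50000 nM, which is a limit of the assay and not a number. Compound 2 thus remains the only compound with a measured number, and the single changes made to it on two different rings both end at the same limit: the limit of > 50000 nM in this assay, at which 2 of the 3 values shown sit.

The compounds shown hold only fluoro and trifluoromethyl at this place, so they do not tell how a hydrogen, a chlorine, a methoxy group or a nitrile would fare there, or whether any group at this place would give a lower number than compound 2 does. Also open is what an amine or a carboxylic acid would do in place of the hydroxyl groups of compound 2, since every compound shown carries hydroxyphenyl groups on the shared core.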